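Acyl chain extension on the aryl sulfonate series

The compounds below may be only part of what the source reports. "The series", "measured", "known", "first", "only" and "open" are said of these compounds alone.

Measured so far:
Compound 1 `CC(=O)Nc1cccc(S(=O)(=O)Oc2ccccc2C(C)C)c1` gives 31000 nM in a functional assay on M21 cells (Homo sapiens) for antiproliferative activity, read by sulforhodamine B assay, with a stated time of 48 h; a higher number here means a weaker inhibitor, a lower number a stronger inhibitor.
Compound 2 `CCCC(=O)Nc1cccc(S(=O)(=O)Oc2ccccc2C(C)C)c1` gives 20000 nM in this assay.

Where compound 2 stands: its number in this assay lies within the scatter of the number for compound 1, since the step of a 1.6-fold lower number from compound 1 to compound 2 (0.19 log units; within the scatter) is within the scatter, so the two compounds cannot be separated on these numbers. For the measured compounds named here, only this one step is available, and both compounds sit in the weak range.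

Compound 3 `CCCCCC(=O)Nc1cccc(S(=O)(=O)Oc2ccccc2C(C)C)c1` is not yet measured. Relative to compound 2 it carries ethyl in place of hydrogen on a saturated chain carbon, three bonds along the chain from a carbonyl carbon, the second extension of the acyl chain in the series. Going by the values given here, the only step that bears on it is a 1.6-fold lower number from compound 1 to compound 2 (0.19 log units; within the scatter), which added the same group on a saturated chain carbon bound to the carbonyl carbon and moved the number by less than the scatter. A change of similar size is expected from compound 2 to compound 3, a 1.4-fold lower number from compound 2 to compound 3 (0.15 log units; within the scatter), toward a lower number, but the step is not expected to exceed the scatter. Compound 3 is therefore estimated at 14000 nM in this assay, with a range of 5000 nM to 40000 nM.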

Compound 3, half-maximal inhibitory concentration: 11000 nM
Compound 3: the middle estimate sits 1.3-fold (0.10 log units) above what was measured; the range from low to high includes it.
By their numbers in this assay, from the lowest: compounds 3, 2 and 1 (each within the scatter of the next, the first and the last beyond it).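

In this assay, the added ethyl, on a saturated chain carbon three bonds along the chain from a carbonyl carbon, gives a step that again stays within the scatter (a 1.8-fold lower number from compound 2 to compound 3 (0.26 log units; within the scatter)), so compound 2 and compound 3 cannot be separated on these numbers. For the compounds shown here, the new information lies in the full change: the whole extension of the chain, taken as a single comparison, gives the first step beyond the scatter (a 2.8-fold lower number from compound 1 to compound 3 (0.45 log units; beyond the scatter)), although only a modest one, so chain length at this position has a measurable link to the number once the two ends of the series are compared, while neither single extension resolves it. No supporting data bear on the origin of this difference.

The compounds shown leave open whether a longer chain would move the number further or whether the trend would stop beyond butyl in place of hydrogen. They also leave open whether an amine, a carboxylic acid or a phenyl ring at the end of the chain would be compatible with this activity on the shared core.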